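The source may report more compounds than this note shows. Statements on the series, on what has been measured and on what is new or still open speak of the compounds shown alone.

Measured compounds:
compound 1, `COC(=O)[C@@]1(C)CCC=C2[C@@H]1CC[C@@H](C)[C@]2(C)Cc1c(C)[nH]c2ccccc12`, 11000 nM
compound 2, `COC(=O)[C@@]1(C)CCC=C2[C@@H]1CC[C@@H](C)[C@]2(C)Cc1c(C=O)[nH]c2ccccc12`, 4400 nM
compound 3, `COC(=O)[C@@]1(C)CC[C@@H]2C3=C1CC[C@@H](C)[C@]3(C)C[C@@H]1c3ccccc3N[C@H]21`, 19000 nM

In a functional assay on HeLa cells (Homo sapiens) for inhibition, read by sulforhodamine B assay, with a stated time of 48 h (on this read-out higher numbers stand for weaker inhibition of growth and lower numbers for stronger inhibition of growth), compound 3 gives the highest of the three numbers. Its gap to compound 1 lies within the usual scatter, so the two cannot be told apart, whereas compound 2 sits below it by a margin beyond the scatter. The only step measured among these compounds is a 2.5-fold lower number from compound 1 to compound 2 (0.40 log units; beyond the scatter), a modest change brought about by a formyl in place of a methyl on an aromatic carbon of the core of compound 1. Compound 4, `COC(=O)[C@@]1(C)CC[C@@H]2C3=C1CC[C@@H](C)[C@]3(C)C[C@@H]1c3cc(OC)ccc3N[C@H]21`, differs from compound 3 by methoxy in place of hydrogen on an aromatic carbon. Among the measured compounds shown here, no measured step touches this ring or this kind of group, so nothing in the data speaks for or against a change, and the expectation in this assay is a step of no more than the scatter, which the estimate a 1.3-fold lower number from compound 3 to compound 4 (0.10 log units; within the scatter) expresses. Compound 4 is therefore expected to give about 15000 nM, with a range from 6000 nM to 40000 nM.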

Compound 4, concentration for 50% growth inhibition: 20000 nM
Compound 4: middle estimate off by 1.3-fold (0.12 log units), on the low side; the measured number falls inside the stated range.
By their numbers in this assay, from the lowest: compound 2; then compounds 1, 3 and 4 (each within the scatter of the next).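

With the methoxy group on this six-membered aromatic ring of carbon only, meta to a fused ring and para to a fused ring, the step in this assay is a 1.1-fold higher number from compound 3 to compound 4 (0.02 log units; within the scatter). Among the compounds shown here, this is the first measured change on this ring, and it shows that, at this one position on the core of compound 3, methoxy and hydrogen cannot be told apart in growth inhibition. Nothing available explains why this exchange leaves the read-out within the scatter.

The compounds shown leave open whether a different group at this position, such as an amine, a carboxylic acid or a longer chain like butoxy, would move the number beyond the scatter. They also leave open whether methoxy would behave the same way on the aromatic ring of compound 2.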